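This account rests on a few compounds, and the source may have more. Where it says the series, first, only, none or still open, it means among the compounds named here.

Measured compounds in a functional assay on K562 cells (Homo sapiens) for antiproliferative activity, read by MTT assay, with a stated time of 48 h; on this read-out lower numbers stand for stronger inhibition and higher numbers for weaker inhibition:
Compound 1 `Cc1ccc(-c2ccc3c(c2)C(=O)C(=O)N3)cc1`: in this assay compound 1 reaches only the limit > 10000 nM (the limit of > 10000 nM in this assay, at which 1 of the 3 values shown sits).
Compound 2 `COc1ccc(-c2ccc3c(c2)C(=O)C(=O)N3)cc1`: compound 2 gives 6920 nM.
Compound 3 `CCN1C(=O)C(=O)c2cc(-c3ccc(OC)cc3)ccc21`: compound 3 gives 2200 nM.

Compound 3 holds the lowest of the two numbers given; the nearest is compound 2, and the step of a 3.1-fold lower number from compound 2 to compound 3 (0.50 log units; beyond the scatter) lies beyond the scatter. That step came with ethyl in place of hydrogen on the amide-type nitrogen in a ring. The earlier step of an at least 1.4-fold lower number from compound 1 to compound 2 (0.15 log units; that floor lies within the scatter) came with methoxy in place of methyl on an aromatic carbon and starts from a limit, so its floor lies within the scatter.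

Compound 4 `COc1ccc(-c2ccc3c(c2)C(=O)C(=O)N3c2ccc(OC)cc2)cc1` differs from compound 3 in one place: 4-methoxyphenyl in place of ethyl on an amide-type nitrogen in a ring. Among the compounds with values here, no measured compound carries an aryl group on this nitrogen, so the only step that bears on the change is a 3.1-fold lower number from compound 2 to compound 3 (0.50 log units; beyond the scatter), which shows that filling this nitrogen was tolerated and helped modestly. A larger group there may carry that further or may not; the direction is uncertain. Compound 4 is therefore estimated at 1500 nM, with a range from 400 nM to 6000 nM. That estimate means an expected step of a 1.5-fold lower number from compound 3 to compound 4 (0.17 log units; within the scatter).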

Compound 4, half-maximal inhibitory concentration: > 10000 nM
Compound 4 was reported as a limit; the forecaster's own chance of this, stated with the estimate: 10%; middle value at least 6.6-fold (0.82 log units) from the limit.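

In this assay, within the data shown here, the amide-type nitrogen in the ring does not accept every group: the earlier compounds showed only that ethyl there was tolerated, whereas 4-methoxyphenyl in its place gives an at least 4.5-fold higher number from compound 3 to compound 4 (0.65 log units; beyond the scatter), a step beyond the scatter that takes back the gain seen with ethyl. Compound 4 reaches only a limit of the assay, as does compound 1: the limit of > 10000 nM in this assay, at which 2 of the 4 values shown sit. Measured against the amide hydrogen, the change reads an at least 1.4-fold higher number from compound 2 to compound 4 (0.15 log units; that floor lies within the scatter), and that floor lies within the scatter, so the data do not show whether 4-methoxyphenyl on this nitrogen is any worse than hydrogen, only that it is clearly worse than ethyl.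

Going by these compounds, it stays open whether a propyl or butyl chain, a benzyl group or a plain phenyl on this nitrogen would hold the level of compound 3 or fall to the limit, which would separate the effect of chain length from that of an aromatic ring. Also open, on these data alone, is how far the true value of compound 4 lies beyond its limit, and whether the methoxy on the entering ring plays any part in the loss.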